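The source may hold more compounds than are shown below. What is called first, only, known or untested is meant among the compounds shown, and "the series" means these compounds.

Measured so far in a functional assay on the whole organism with Canis familiaris (Canis lupus familiaris) as the target, at a dose of 8 mg/kg by the oral route; a higher number here means a stronger effect of the compound at the dose given, a lower number a weaker effect:
compound 1 `Cc1nc2c(OCc3ccccc3)cccn2c1N` gives 96%
compound 2 `CC(C)c1nc2c(OCc3ccccc3)cccn2c1N` gives 0%

Going by the values given here, compound 1 stands highest of the two numbers; its nearest neighbour is compound 2, and the one recorded step is a number 96 percentage points lower from compound 1 to compound 2 (beyond the scatter), isopropyl in place of methyl on an aromatic carbon. Compound 3 `Cc1nc2c(OCc3ccc(C(F)(F)F)cc3)cccn2c1N` is not yet measured. Among the compounds with values here, it differs from compound 1 by trifluoromethyl in place of hydrogen on an aromatic carbon, a change on the six-membered aromatic ring of carbon only, not at the place of the recorded step, so that step does not bear on it and the series holds no step of the same kind. Within the data shown here, the only anchor is the value of compound 1, which leaves little room upward. Because compound 1 already gives 96%, compound 3 is expected to stay near that level, with a step of a number 16 percentage points lower from compound 1 to compound 3 (beyond the scatter). Compound 3 is estimated at 80%, range 40% to 100%.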

Compound 3, a percentage reported as inhibition, in the whole organism at one dose (the size of the read-out at that dose, not a potency): 8%
Compound 3: the middle estimate sits 72 percentage points above what was measured; the measured number lies below the stated range.
By their numbers in this assay, from the lowest: compounds 2 and 3 (each within the scatter of the next); then compound 1.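

In this assay, trifluoromethyl in place of hydrogen on an aromatic carbon of the six-membered aromatic ring of carbon only, para to a large group, comes with a number 88 percentage points lower from compound 1 to compound 3 (beyond the scatter). The read-out at this dose is therefore sensitive to change on this ring as well as at the place of the earlier isopropyl step, and the high number of compound 1 is retained at neither place. No measurement at hand bears on why the read-out falls with this change.

Open, on these data alone, is whether a fluorine atom or a methoxy group at the same place would retain the read-out, which would help separate the place from the particular group. Also open, as far as these compounds go, is whether trifluoromethyl elsewhere on this ring would give a similar result.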